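Methoxycarbonyl in place of thiophen-2-yl on the core

The compounds below may be only part of what the source reports. "The series", "measured", "known", "first", "only" and "open" are said of these compounds alone.

Compound 1 `CCCCCCCCc1ccc(OCC(=O)Cn2nnc(-c3ccc(C(=O)OC)cc3)n2)cc1`: 29 nM
Compound 2 `CCCCCCCCc1ccc(OCC(=O)Cn2nnc(-c3cccc(C(=O)OC)c3)n2)cc1`: 34 nM
Compound 3 `CCCCCCCCc1ccc(OCC(=O)Cn2nnc(-c3cccs3)n2)cc1`: 32 nM

In an assay on microsomes from brain for inhibition of Fatty-acid amide hydrolase 1 (Rattus norvegicus), read by fluorescence and HPLC, with a stated time of 60 min (a higher number here means a weaker inhibitor, a lower number a stronger inhibitor), the three measured compounds lie close together. Compound 3 stands in the middle of them: the change from compound 2 to compound 3 gives a 1.1-fold lower number from compound 2 to compound 3 (0.03 log units; within the scatter), and the change from compound 1 to compound 3 gives a 1.1-fold higher number from compound 1 to compound 3 (0.04 log units; within the scatter), so compound 3 is within the scatter of both neighbours. The move from compound 1 to compound 2, a 1.2-fold higher number from compound 1 to compound 2 (0.07 log units; within the scatter), is also within the scatter.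

Compound 4 `CCCCCCCCc1ccc(OCC(=O)Cn2nnc(C(=O)OC)n2)cc1` differs from compound 3 as follows: methoxycarbonyl in place of thiophen-2-yl on an aromatic carbon. Every measured step swaps one aromatic group on that carbon for another, and none of them moved this assay beyond the scatter. None removes the aromatic ring altogether as this change does, so the measured steps bear on it only loosely. A small shift toward a higher number seems more likely than none, since the exchanges so far kept a ring there. Compound 4 is therefore expected to give about 80 nM in this assay, within 25 nM to 300 nM, which would mean an expected step of a 2.5-fold higher number from compound 3 to compound 4 (0.40 log units; beyond the scatter).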

Compound 4, half-maximal inhibitory concentration: 88 nM
Estimate against measurement, compound 4: 1.1-fold (0.04 log units) below; the measured number falls inside the stated range.
By their numbers in this assay, from the lowest: compounds 1, 3 and 2 (each within the scatter of the next); then compound 4.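

In this assay, among the compounds shown here, this aromatic carbon had taken a thiophen-2-yl and both methoxycarbonyl-substituted phenyl groups without any step beyond the scatter, but a methoxycarbonyl group with no ring gives the first step that lies beyond it (a 2.8-fold higher number from compound 3 to compound 4 (0.44 log units; beyond the scatter)). The same replacement gives modest steps from the two phenyl compounds as well (a 2.6-fold higher number from compound 2 to compound 4 (0.41 log units; beyond the scatter); a 3.0-fold higher number from compound 1 to compound 4 (0.48 log units; beyond the scatter)), which makes compound 4 the weakest inhibitor of the four. Compound 1 and compound 2 carry a methoxycarbonyl group on their phenyl rings while compound 3 has none, and these three stay within the scatter of one another, so among these compounds the loss of the aromatic ring at this carbon, not the presence of the ester alone, goes with the weaker inhibition.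

No evidence is available to explain this step. The compounds shown leave open whether a methyl group or a longer alkyl chain at this carbon would behave like compound 4, and whether a carboxylic acid or a primary amide in place of the methyl ester would shift the value further.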